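Working notes: biaryl variation and measured lipophilicity

This account rests on a few compounds, and the source may have more. Where it says the series, first, only, none or still open, it means among the compounds named here.

Three compounds of the series carry the shared core with a varied aryl group. Compound 1 `CC[C@@H](Nc1c(C#N)c(-c2ccc(-c3ccc(F)cc3)cc2)nc2cnccc12)C(N)=O` gives 2.7 in a physicochemical assay for lipophilicity, read by HPLC, at pH 7.5; on this read-out higher numbers stand for higher lipophilicity and lower numbers for lower lipophilicity. Compound 2 `CC[C@@H](Nc1c(C#N)c(-c2ccc(-c3ccccc3C(C)C)cc2)nc2cnccc12)C(N)=O` gives 3.5 in this assay, and the step of a number 0.80 log units higher from compound 1 to compound 2 (beyond the scatter) is the largest change recorded so far. Compound 3 `CC[C@@H](Nc1c(C#N)c(-c2ccc(-c3ccccc3COC)cc2)nc2cnccc12)C(N)=O` gives 2.6 in this assay, the lowest of the three numbers; its difference from compound 1, a number 0.10 log units lower from compound 1 to compound 3 (within the scatter), is within the scatter, while from compound 2 the step is a number 0.90 log units lower from compound 2 to compound 3 (beyond the scatter).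

Compound 4 `CC[C@@H](Nc1c(C#N)c(-c2ccc(-c3cccc(Cl)c3OC)cc2)nc2cnccc12)C(N)=O` is not yet measured in this assay. It differs from compound 3 as follows: 3-chloro-2-methoxyphenyl in place of 2-(methoxymethyl)phenyl on an aromatic carbon. Among the measured compounds shown here, no measured pair shows exactly this exchange. For the measured compounds named here, the steps that bear on it are the exchange of the aryl group in compound 1 for those of compound 2 and compound 3, and the step of a number 0.90 log units lower from compound 2 to compound 3 (beyond the scatter), which shows that the substituent pattern on this ring can move the read-out by a modest amount. The incoming ring carries a chlorine and a methoxy group, and the expected step from compound 3 is estimated at a number 0.60 log units higher from compound 3 to compound 4 (beyond the scatter), upward. Compound 4 is therefore expected to give about 3.2 in this assay, within a range from 2.8 to 3.6.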

Compound 4, distribution coefficient: 3.1
The estimate for compound 4 lay 0.10 log units above the measured number, and the stated range covers the measured number.
By their numbers in this assay, from the lowest: compounds 3 and 1 (each within the scatter of the next); then compound 4; then compound 2.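

Working notes on the result: at this position, on an aromatic carbon para to a large group, the exchange of 2-(methoxymethyl)phenyl for 3-chloro-2-methoxyphenyl gives a number 0.50 log units higher from compound 3 to compound 4 (beyond the scatter) in this assay even though the two groups match in heavy-atom count and in hydrogen-bond acceptors, so these matching counts do not fix the read-out in this pair. The two remaining comparisons place the new aryl group at an intermediate level, with a number 0.40 log units higher from compound 1 to compound 4 (beyond the scatter) on one side and a number 0.40 log units lower from compound 2 to compound 4 (beyond the scatter) on the other, so the read-out in this set is no longer split only between compound 2 and the pair of compound 1 and compound 3. No measurement at hand explains the size of these steps.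

The compounds shown leave open how much of the step from the 2-(methoxymethyl)phenyl group belongs to the chlorine and how much to the methoxy group, as no pair here separates the two. Also open, from the compounds shown here alone, is how this assay responds when the ring at this position carries an amine or a carboxylic acid.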